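The compounds below may be only part of what the source reports. "The series", "measured", "known", "first", "only" and "open" are said of these compounds alone.

Of the compounds shown here, three sharing one core have been measured in an assay on CHO cells for displacement of a labelled ligand from adenosine receptor A3 (Homo sapiens), read by scintillation counting, with a stated time of 3 h; a higher number here means a weaker inhibitor, a lower number a stronger inhibitor. Compound 1 `Cn1c(-c2ccc(F)cc2)nc2c(NC3CCCC3)ncnc21` gives 1140 nM. Compound 2 `CCn1c(-c2ccccc2)nc2c(NC3CCC3)ncnc21` gives 84 nM. Compound 3 `CCCn1c(-c2ccccc2)nc2c(NC3CCC3)ncnc21` gives 264 nM, which places it second highest of the three numbers: the step of a 3.1-fold higher number from compound 2 to compound 3 (0.50 log units; beyond the scatter) separates it from compound 2, and compound 1 stands further off with a higher number. Compound 4 `CCCn1c(-c2ccccc2)nc2c(NC3CCCCC3)ncnc21` keeps everything in compound 3 except one change: cyclohexyl in place of cyclobutyl on a nitrogen on an aromatic ring. Going by the values given here, none of the measured steps bears on this change. Among the compounds with values here, the one step in hand, a 3.1-fold higher number from compound 2 to compound 3 (0.50 log units; beyond the scatter), concerns a different part of the molecule, and compound 1, which differs from compound 3 in more than one place, offers no step that could be tied to the ring alone. With no direct guide, the number for compound 4 in this assay is expected to lie near that of compound 3. The step of a 1.1-fold lower number from compound 3 to compound 4 (0.02 log units; within the scatter) is therefore expected to be small, in either direction, and most likely within the scatter. Compound 4 is estimated at 250 nM, with a range from 60 nM to 1000 nM in this assay.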

Compound 4, inhibition constant: 2360 nM
Estimate against measurement, compound 4: 9.4-fold (0.97 log units) below; the measured number lies above the stated range.
By their numbers in this assay, from the lowest: compound 2; then compound 3; then compound 1; then compound 4.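

Going by these compounds alone, this is the first step that bears on the group on this nitrogen, and it shows that the position is sensitive to the change: in this assay, with the propyl chain and the rest of the molecule held constant, cyclohexyl in place of cyclobutyl gives an 8.9-fold higher number from compound 3 to compound 4 (0.95 log units; beyond the scatter). The larger ring therefore makes compound 4 a clearly weaker inhibitor than compound 3, although this rests on a single pair of compounds. No supporting data are available to explain why this swap weakens the inhibitor.

Going by these compounds, it remains open whether the number rises steadily with ring size, as cyclopentyl appears only in compound 1, which differs from compound 3 in other places too. A smaller cyclopropyl ring or an open-chain butyl group on this nitrogen would show whether ring size itself matters.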